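Replacing a sulfide with a dialkylamino group on a shared core

The source may report more compounds than this note shows. Statements on the series, on what has been measured and on what is new or still open speak of the compounds shown alone.

Three compounds share one core and differ only in a single group on an aromatic carbon. Compound 3 `CCc1nc(-c2ccc(Cl)cc2Cl)c(CC)nc1SC(C)CC` carries a (sec-butyl)sulfanyl group there and gives 401 nM in an assay on IMR-32 cells for displacement of a labelled ligand from corticotropin-releasing factor receptor 1 (Homo sapiens), read by scintillation counting, with a stated time of 2 h (on this read-out lower numbers stand for stronger inhibition and higher numbers for weaker inhibition), the highest of the three numbers. Compound 1 `CCc1nc(-c2ccc(Cl)cc2Cl)c(CC)nc1NC(COC)COC` carries a (2-methoxy-1-(methoxymethyl)ethyl)amino group and gives 224 nM; the step of a 1.8-fold higher number from compound 1 to compound 3 (0.25 log units; within the scatter) therefore stays within the scatter. Compound 2 `CCc1nc(-c2ccc(Cl)cc2Cl)c(CC)nc1CC(CC)CC` carries a 2-ethylbutyl group and gives 68 nM, and the step of a 5.9-fold higher number from compound 2 to compound 3 (0.77 log units; beyond the scatter) is the one clear difference among the three.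

Compound 4 `CCCN(CC1CC1)c1nc(CC)c(-c2ccc(Cl)cc2Cl)nc1CC` has not been measured. It differs from compound 3 in one place: (cyclopropylmethyl)(propyl)amino in place of (sec-butyl)sulfanyl on an aromatic carbon. The change brings a larger group, closer in size to the 2-ethylbutyl group of compound 2, and restores a nitrogen attached to the ring, as in compound 1. The step of a 5.9-fold higher number from compound 2 to compound 3 (0.77 log units; beyond the scatter) is the one that bears most on the change, since it shows that a larger hydrocarbon-rich group at this position gave a lower number; the step of a 1.8-fold higher number from compound 1 to compound 3 (0.25 log units; within the scatter) suggests that a nitrogen alone adds little beyond the scatter.

Compound 4 is therefore expected to give a lower number than compound 3, a step of about an 8.9-fold lower number from compound 3 to compound 4 (0.95 log units; beyond the scatter), with an estimated value of 45 nM and a range from 12 nM to 180 nM.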

Compound 4, inhibition constant: 19.2 nM
Compound 4: middle estimate off by 2.3-fold (0.37 log units), on the high side; low and high end bracket the measured number.
By their numbers in this assay, from the lowest: compound 4; then compound 2; then compounds 1 and 3 (each within the scatter of the next).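

In this assay, the (cyclopropylmethyl)(propyl)amino group gives the lowest number of the four compounds, with a 21-fold lower number from compound 3 to compound 4 (1.32 log units; beyond the scatter) and a 3.5-fold lower number from compound 2 to compound 4 (0.55 log units; beyond the scatter), so the 2-ethylbutyl group no longer marks the best result seen at this position. Compounds 1 and 4 both attach a nitrogen to the ring, yet the number still falls with a 12-fold lower number from compound 1 to compound 4 (1.07 log units; beyond the scatter), which shows that a ring-bound nitrogen does not set the number by itself and that the groups carried on that nitrogen matter a great deal. The data shown include no measurement that explains why these changes move the number.

Compound 4 differs from compound 1 in both groups on the nitrogen, so these compounds cannot separate the contribution of the cyclopropylmethyl group from that of the propyl group; a dipropylamino group at the same place would help to do so. The compounds shown also leave open how a sec-butoxy group, with oxygen in place of the sulfur of compound 3, would compare.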